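The compounds below may be only part of what the source reports. "The series", "measured", "known", "first", "only" and "open" are said of these compounds alone.

Compound 1 `Cc1cc(C(=O)O)c(C)n1CC1CC1` gives in an assay on cells for inhibition of Palmitoleoyl-protein carboxylesterase NOTUM variant C330S (Homo sapiens), read by fluorescence, with a stated time of 40 min (a higher number here means a weaker inhibitor, a lower number a stronger inhibitor), a value of 12700 nM.
Compound 2 `Cc1cc(C(=O)O)c(C)[nH]1` gives in this assay only the limit > 100000 nM.

For compound 2 no number exists in this assay, only a limit, namely (the limit of > 100000 nM in this assay, at which 1 of the 2 values shown sits). Compound 2 therefore sits at the weak end of the two measured compounds, since an at least 7.8-fold higher number from compound 1 to compound 2 (0.89 log units; beyond the scatter) is a step beyond the usual scatter. Within the data shown here, that step, which replaces the cyclopropylmethyl group of compound 1 with a hydrogen on the aromatic nitrogen, is the only measured change that bears on the move to compound 3 `Cc1cc(C(=O)O)c(C)n1C`. From compound 2 to compound 3 the change is methyl in place of hydrogen on an aromatic nitrogen; it puts a substituent back on the same nitrogen, but a smaller one than the cyclopropylmethyl of compound 1. Because removing the cyclopropylmethyl cost the step of an at least 7.8-fold higher number from compound 1 to compound 2 (0.89 log units; beyond the scatter), putting a methyl in its place is expected to lower the number in this assay, though by less than that full step, so compound 3 should land between the two measured compounds. Compound 3 is estimated at 50000 nM, with a range from 15000 nM to 150000 nM. The expected step on this estimate is an at least 2.0-fold lower number from compound 2 to compound 3 (0.30 log units; that floor lies within the scatter).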

Compound 3, half-maximal inhibitory concentration: > 100000 nM
Compound 3 was reported as a limit; the forecaster's own chance of this, stated with the estimate: 40%; middle value at least 2.0-fold (0.30 log units) from the limit.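

Compound 3, like compound 2, is reported in this assay only as a limit, so the step between them cannot be read, and neither compound can be ranked against the other. Two of the three compounds now rest at the same ceiling of the assay: the limit of > 100000 nM in this assay, at which 2 of the 3 values shown sit. Among these compounds, the one readable comparison comes from taking the cyclopropyl off the saturated chain carbon bound to the aromatic nitrogen, which gives an at least 7.8-fold higher number from compound 1 to compound 3 (0.89 log units; beyond the scatter), so a single methyl on that nitrogen does not keep the measurable inhibition of compound 1, and merely having a carbon group there is not enough.

On these data alone, how much of the cyclopropylmethyl group is needed stays open, since any small gain from the methyl would lie hidden behind the limit. Whether an ethyl, a longer chain such as butyl, or a larger ring such as cyclohexylmethyl on the same nitrogen would give a readable number, and so separate the length of the chain from the presence of a ring, the compounds shown do not tell.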